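A few compounds are considered here, and "the series" means these few. Any claim that something is new, unique, unknown or untested is made for them only; others in the source may bear on it.

Measured so far:
- compound 1 `Cc1cc(S(N)(=O)=O)ccc1NC(=O)COc1ccc(Cl)cc1NC(=O)c1cccc(F)c1` gives 243000 nM 
- compound 2 `COc1ccc(C(=O)Nc2cc(Cl)ccc2OCC(=O)Nc2ccc(S(N)(=O)=O)cc2C)cc1` gives 69500 nM 

In a functional assay on C8166 cells (Homo sapiens) for cytotoxicity, read by MTT assay (on this read-out higher numbers stand for lower toxicity in this test and lower numbers for higher toxicity in this test), compound 2 has the lower of the two numbers, which marks it as the more toxic of the pair. Compound 3 `Cc1cc(C)cc(C(=O)Nc2cc(Cl)ccc2OCC(=O)Nc2ccc(S(N)(=O)=O)cc2C)c1` differs from compound 2 by one change 3,5-dimethylphenyl in place of 4-methoxyphenyl on a carbonyl carbon with 3,5-dimethylphenyl in place of 4-methoxyphenyl on a carbonyl carbon. For the measured compounds named here, the only measured step at this place is a 3.5-fold lower number from compound 1 to compound 2 (0.54 log units; beyond the scatter) and it was modest. With that single guide, a modest rise in this assay is expected, though its direction is uncertain. The expected change is a 1.6-fold higher number from compound 2 to compound 3 (0.20 log units; within the scatter) and remains an estimate. The estimate for compound 3 is 110000 nM with an expected range from 45000 nM to 260000 nM for the measurement.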

Compound 3, half-maximal cytotoxic concentration: 36500 nM
Estimate against measurement, compound 3: 3.0-fold (0.48 log units) above; measured number below the stated range.
By their numbers in this assay, from the lowest: compounds 3 and 2 (each within the scatter of the next); then compound 1.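

In this assay, replacing the 4-methoxyphenyl group on the carbonyl carbon with 3,5-dimethylphenyl gives a 1.9-fold lower number from compound 2 to compound 3 (0.28 log units; within the scatter), so removing that hydrogen-bond acceptor produces no readable difference here. Replacing 3-fluorophenyl with the same group gives a 6.7-fold lower number from compound 1 to compound 3 (0.82 log units; beyond the scatter), which leaves compound 1 apart from the other two compounds. Nothing measured here explains these numbers. Going by these compounds, it remains open how this place would respond to an amine or a carboxylic acid on the aromatic ring, or to a cyclohexyl group replacing that ring.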